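Swapping a nitrophenyl for a hydroxyphenyl on the hydrazone

The compounds below may be only part of what the source reports. "The series", "measured", "known", "first", "only" and "open" are said of these compounds alone.

Of the compounds shown here, three sharing one core have been tested in a functional assay on HepG2 cells (Homo sapiens) for cytotoxicity, read by MTT assay, with a stated time of 48 h; a lower number here means a stronger inhibitor, a higher number a weaker inhibitor. The smallest, compound 1 `NNC(=O)CSc1nnc(-c2ccncc2)o1`, gives 3260 nM. Compound 3 `O=C(CSc1nnc(-c2ccncc2)o1)N/N=C/c1cccc(C(F)(F)F)c1`, which carries a trifluoromethyl-bearing ring on the hydrazone, gives 6520 nM. Compound 2 `O=C(CSc1nnc(-c2ccncc2)o1)N/N=C/c1ccc([N+](=O)[O-])cc1` gives 17900 nM, the highest of the three numbers and therefore the weakest inhibitor here, with compound 3 nearest to it and compound 1 furthest away, both gaps lying beyond the scatter of the assay.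

Compound 4 `O=C(CSc1nnc(-c2ccncc2)o1)N/N=C/c1ccccc1O` has not yet been measured. It differs from compound 2 in one place: 2-hydroxyphenyl in place of 4-nitrophenyl on a carbon with a double bond to nitrogen. Within the data shown here, no measured pair in this set shows what such a change does on its own, so the expectation rests on the spread of the three numbers. Since the two compounds carrying other groups on this carbon, compound 1 with 3260 nM and compound 3 with 6520 nM, both sit lower than compound 2, a modest move toward lower numbers is expected for compound 4, a step of a 2.2-fold lower number from compound 2 to compound 4 (0.35 log units; beyond the scatter). Compound 4 is thus estimated at 8000 nM, within a range from 3000 nM to 25000 nM.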

Compound 4, half-maximal inhibitory concentration: 3510 nM
Compound 4: middle estimate off by 2.3-fold (0.36 log units), on the high side, within the range that was stated.
By their numbers in this assay, from the lowest: compounds 1, 4 and 3 (each within the scatter of the next); then compound 2.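

The swap of 4-nitrophenyl for 2-hydroxyphenyl on a carbon with a double bond to nitrogen gives a 5.1-fold lower number from compound 2 to compound 4 (0.71 log units; beyond the scatter) in this assay, so a change at this one place can by itself move the number beyond the scatter. Compound 4 (3510 nM) lies within the scatter of both compound 1 (3260 nM) and compound 3 (6520 nM), which leaves compound 2 as the only one set apart from the others, as the weakest of the four. Nothing measured here explains the step.

From the compounds shown here alone, the change removes a nitro group and adds a hydroxyl on a different ring position in a single move, so the contribution of each part remains open. A plain phenyl ring, or an amine in place of the hydroxyl, would help to separate these contributions.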